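The source may hold more compounds than are shown below. What is called first, only, known or untested is meant among the compounds shown, and "the series" means these compounds.

Measured compounds:
- compound 1, `CC(=O)Nc1ccc(NC(=O)c2cc(Cl)ccc2O)c(Cl)c1`: "not determined" (no result reported) in an ADME assay on A549 cells (Homo sapiens) for cytotoxicity, read by resazurin assay, with a stated time of 48 h; a lower number here means that less compound is tolerated, a higher number that more compound is tolerated
- compound 2, `CC(C)CNc1ccc(NC(=O)c2cc(Cl)ccc2O)c(Cl)c1`: 60000 nM
- compound 3, `O=C(Nc1ccc(N(CC2CC2)CC2CC2)cc1Cl)c1cc(Cl)ccc1O`: 12800 nM

Three compounds share the core of compound 1, and two of them carry a number in this assay. Compound 2 stands highest of the two numbers, so it is the compound of which the most is tolerated. Its nearest neighbour is compound 3, and the step between them is a 4.7-fold lower number from compound 2 to compound 3 (0.67 log units; beyond the scatter), a change on an aromatic carbon in which a larger amine takes the place of a smaller one.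

Compound 4, `CN(C)c1ccc(CNc2ccc(NC(=O)c3cc(Cl)ccc3O)c(Cl)c2)cc1`, is not yet measured. It differs from compound 2 in one place: 4-(dimethylamino)phenyl in place of isopropyl on a saturated chain carbon bound to a nitrogen on an aromatic ring. For the measured compounds named here, the only measured step that bears on this is the one from compound 2 to compound 3, where enlarging the group on the nitrogen went with a lower number, beyond the scatter. Going by the values given here, since compound 4 also carries a larger group at the nitrogen than compound 2, a step in the same direction and of similar, modest size is expected, though the group entering here is of a different kind and no step with such a group is known. Compound 4 is therefore estimated at 25000 nM, with a range from 8000 nM to 70000 nM, which means an expected step of a 2.4-fold lower number from compound 2 to compound 4 (0.38 log units; beyond the scatter).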

Compound 4, half-maximal cytotoxic concentration: 24500 nM
Estimate against measurement, compound 4: 1.0-fold (0.01 log units) above, and the stated range covers the measured number.
By their numbers in this assay, from the lowest: compounds 3 and 4 (each within the scatter of the next); then compound 2.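

In this assay, replacing isopropyl with 4-(dimethylamino)phenyl on a saturated chain carbon bound to a nitrogen on an aromatic ring gives a 2.4-fold lower number from compound 2 to compound 4 (0.39 log units; beyond the scatter), so this position now has a second change that lowers the number, alongside a 4.7-fold lower number from compound 2 to compound 3 (0.67 log units; beyond the scatter). Compound 3 carries two cyclopropylmethyl groups on the nitrogen, whereas compound 4 keeps a single substituent there, which shows that a second group on the nitrogen is not required for a lower number than that of compound 2, and that an aromatic ring in the entering group is compatible with such a step. No measurement shown accounts for either step.

Whether the ring itself or its dimethylamino group goes with the lower number stays open, since a plain benzyl group on the same nitrogen is not among the compounds shown. As far as these compounds go, it is also open whether a polar group such as a carboxylic acid on that ring, or a longer saturated chain in place of isopropyl, would move the number the same way.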